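Working notes: 4-chlorophenyl to 4-bromophenyl

The source may report more compounds than this note shows. Statements on the series, on what has been measured and on what is new or still open speak of the compounds shown alone.

In a functional assay on HeLa cells (Homo sapiens) for inhibition, read by MTT assay, with a stated time of 72 h (a higher number here means a weaker inhibitor, a lower number a stronger inhibitor), the series holds three values: compound 1 (`O=[N+]([O-])c1ccc(-c2nnc(SCCCN3CCN(c4nc5ccccc5s4)CC3)o2)cc1`) at 97800 nM (nitro), compound 2 (`Cc1ccc(-c2nnc(SCCCN3CCN(c4nc5ccccc5s4)CC3)o2)cc1`) at 179000 nM (methyl) and compound 3 (`Clc1ccc(-c2nnc(SCCCN3CCN(c4nc5ccccc5s4)CC3)o2)cc1`) at 177000 nM (chloro). Compound 3 therefore stands level with compound 2 and within the scatter of compound 1.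

The next compound, compound 4 (`Brc1ccc(-c2nnc(SCCCN3CCN(c4nc5ccccc5s4)CC3)o2)cc1`), differs from compound 3 by one substituent: bromo in place of chloro on an aromatic carbon (bromo in place of chloro on an aromatic carbon, para to a large group). No replacement of one halogen by another has been measured in this series, so the evidence is indirect. Three measured steps at this same place bear on it. The step of a 1.0-fold lower number from compound 2 to compound 3 (0.00 log units; within the scatter) (chloro in place of methyl), the step of a 1.8-fold higher number from compound 1 to compound 3 (0.26 log units; within the scatter) (chloro in place of nitro) and the step of a 1.8-fold higher number from compound 1 to compound 2 (0.26 log units; within the scatter) (methyl in place of nitro) all stay within the scatter. Among these three compounds, no replacement at this place has yet moved the number beyond the scatter.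

No step beyond the scatter is expected in this assay for this replacement, and the expected change, a 1.0-fold lower number from compound 3 to compound 4 (0.02 log units; within the scatter), has no firm direction. The estimate for compound 4 is 170000 nM with 90000 nM to 320000 nM as the expected range.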

Compound 4, half-maximal inhibitory concentration: 243000 nM
Compound 4: the middle estimate sits 1.4-fold (0.16 log units) below what was measured, and the stated range covers the measured number.
By their numbers in this assay, from the lowest: compounds 1, 3, 2 and 4 (each within the scatter of the next, the first and the last beyond it).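

At this position, on an aromatic carbon para to a large group, this assay now has a replacement of one halogen by another, and bromo in place of chloro gives (a 1.4-fold higher number from compound 3 to compound 4 (0.14 log units; within the scatter)), which leaves compound 3 and compound 4 indistinguishable. Bromo in place of methyl likewise stays small (a 1.4-fold higher number from compound 2 to compound 4 (0.13 log units; within the scatter)), so chloro, methyl and bromo cannot be told apart here, whereas bromo in place of nitro gives (a 2.5-fold higher number from compound 1 to compound 4 (0.40 log units; beyond the scatter)), the only step at this place so far to pass beyond the scatter, and a modest one; nitro in compound 1 stays within the scatter of both chloro and methyl, so this separation holds only against bromo, and the four compounds form an overlapping run, not distinct groups. Nothing available explains any of these steps.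

The compounds shown leave open whether a quite different group at this place, such as an amine or a carboxylic acid, would move the number further than any of these four substituents does. As far as these compounds go, all four also share the same core, so the effect of a change elsewhere, such as a longer chain, remains open.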